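Swapping chloro for trifluoromethyl on a weak cytotoxic amide

The source may hold more compounds than are shown below. What is called first, only, known or untested is meant among the compounds shown, and "the series" means these compounds.

Measured compounds:
- compound 1, `O=C(CN1CCN(c2nnc(Cc3ccncc3)c3ccccc23)CC1)Nc1ccc(F)c(Cl)c1`, 12300 nM
- compound 2, `Cc1ccc(F)cc1NC(=O)CN1CCN(c2nnc(Cc3ccccc3)c3ccccc23)CC1`, "not active" (no number reported)
- compound 3, `COc1ccc(NC(=O)CN2CCN(c3nnc(Cc4ccccc4)c4ccccc34)CC2)cc1OC`, "not active" (no number reported)

The three measured compounds share one core and differ in the aryl group on the amide. In a functional assay on A549 cells (Homo sapiens) for cytotoxicity, read by MTT assay, with a stated time of 72 h (a lower number here means a stronger inhibitor, a higher number a weaker inhibitor), compound 1 gives 12300 nM, the only numerical result among the three. Compound 2 is reported in this assay as "not active" (no number reported), and compound 3 likewise as "not active" (no number reported). Compound 1 therefore stands alone as the one entry with a measurable, if weak, effect.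

The unmeasured compound 4, `O=C(CN1CCN(c2nnc(Cc3ccncc3)c3ccccc23)CC1)Nc1ccc(F)c(C(F)(F)F)c1`, keeps everything else of compound 1 and changes one substituent: trifluoromethyl in place of chloro on an aromatic carbon. Within the data shown here, nothing in the measured set shows what this particular swap does, so there is no step to lean on.

Among the measured compounds shown here, with only a single number to anchor the series, the expectation for compound 4 is modest: a step from compound 1 that stays close to or slightly beyond the scatter, most likely toward a somewhat lower concentration, a 1.5-fold lower number from compound 1 to compound 4 (0.19 log units; within the scatter). On that basis compound 4 is estimated at 8000 nM in this assay, with a plausible range from 3000 nM to 30000 nM.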

Compound 4, half-maximal inhibitory concentration: 16000 nM
The estimate for compound 4 lay 2.0-fold (0.30 log units) below the measured number; the range from low to high includes it.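

In this assay, the step from chloro to trifluoromethyl is a 1.3-fold higher number from compound 1 to compound 4 (0.11 log units; within the scatter), so the two compounds cannot be told apart here. Among these compounds, this is the first direct look at this position, on an aromatic carbon ortho to a fluoro group: the amide's aryl ring accepts a group of 4 heavy atoms in place of one of 1 heavy atom, and a measurable number remains, with no readable gain or loss. No measurement of any property of these compounds is available to explain this result.

On these data alone, whether a nitrile or an amine at this same place would give a number clearly apart from that of compound 1 remains open, since two substituents that read alike say little about the full range the position allows. Compound 2 and compound 3 also differ from compound 1 in more than one place and carry no number. They cannot show which part of the structure decides between a measurable value and a "not active" entry.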